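From 1-acetylazetidin-3-yl to 1-methylpyrrolidin-3-yl

The compounds below may be only part of what the source reports. "The series", "measured", "known", "first", "only" and "open" are said of these compounds alone.

Measured in an ADME assay on microsomes from liver (Mus musculus, strain CD-1) for metabolic stability, read by LC-MS, tested at 2 uM; a lower number here means that the compound disappears faster, a higher number that the compound lasts longer:
- compound 1 `CC(=O)N1CCC(NC(=O)c2ccncc2Nc2cc(-c3ccc4ccn(C)c4c3)c3nccnc3c2)CC1`: 0.117 h
- compound 2 `CC(=O)N1CC(NC(=O)c2ccncc2Nc2cc(-c3ccc4ccn(C)c4c3)c3nccnc3c2)C1`: 0.817 h
- compound 3 `CC(=O)N1CC(CNC(=O)c2ccncc2Nc2cc(-c3ccc4ccn(C)c4c3)c3nccnc3c2)C1`: > 1 h

Compound 3 gives > 1 h, which is a limit and not a number. It stands at the limit of > 1 h in this assay, at which 1 of the 3 values shown sits.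

The three compounds share a core and differ only in the group on the amide-type nitrogen. Putting 1-acetylazetidin-3-yl in place of 1-acetylpiperidin-4-yl gave a 7.0-fold higher number from compound 1 to compound 2 (0.84 log units; beyond the scatter). The (1-acetylazetidin-3-yl)methyl group gave an at least 8.5-fold higher number from compound 1 to compound 3 (0.93 log units; beyond the scatter). The remaining comparison, an at least 1.2-fold higher number from compound 2 to compound 3 (0.08 log units; that floor lies within the scatter), sets no order between those two compounds.

Compound 4 `CN1CCC(CNC(=O)c2ccncc2Nc2cc(-c3ccc4ccn(C)c4c3)c3nccnc3c2)C1` keeps the chain carbon bound to the amide-type nitrogen but carries 1-methylpyrrolidin-3-yl in place of 1-acetylazetidin-3-yl on a saturated chain carbon bound to an amide-type nitrogen. Going by the values given here, no measured step removes the acetyl group, so this part of the change has no direct guide in this assay. The change of ring has one: compound 1, with the larger ring, lies on the low side of an at least 8.5-fold higher number from compound 1 to compound 3 (0.93 log units; beyond the scatter), and this suggests that part of that difference may be given back. The step expected is an at least 2.5-fold lower number from compound 3 to compound 4 (0.39 log units; beyond the scatter), modest in size and towards a lower number.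

Compound 4 is estimated at 0.4 h, with an expected range of 0.13 h to 1.1 h.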

Compound 4, half-life: > 1 h
Compound 4: only a limit was reported; the forecaster's own chance of this, stated with the estimate: 15%; at least 2.5-fold (0.39 log units) between middle value and limit.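

In this assay compound 4 gives > 1 h, which is a limit and not a number, and it joins compound 3 at the top of what this read-out can show: the limit of > 1 h in this assay, at which 2 of the 4 values shown sit. The new group therefore keeps the distance from the 1-acetylpiperidin-4-yl group, with an at least 8.5-fold higher number from compound 1 to compound 4 (0.93 log units; beyond the scatter), and shows that an acetyl group on the ring nitrogen is not needed on this chain for a compound to reach the limit, while an at least 1.2-fold higher number from compound 2 to compound 4 (0.08 log units; that floor lies within the scatter) sets no order between those two compounds. The step between compound 3 and compound 4 cannot be read, since both stand only at a limit.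

Going by these compounds, how long compound 3 and compound 4 last past that limit stays open, and with it any order between them. On these data alone, the change from compound 3 to compound 4 also alters the ring size and the group on the ring nitrogen together, so the share of each stays unknown, and the 1-methylazetidin-3-yl and 1-acetylpyrrolidin-3-yl groups on the same saturated chain carbon would be the ones to pull the two apart.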